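Cytotoxicity notes on the shared core series

A few compounds are considered here, and "the series" means these few. Any claim that something is new, unique, unknown or untested is made for them only; others in the source may bear on it.

Measured so far:
compound 1 `Cc1c(-c2ccc(Cc3ccc(C(C)(O)C(F)(F)F)cc3)cc2)[nH]c2cccc(F)c2c1=O` gives > 2500 nM, a limit of the assay.
compound 2 `Cc1c(-c2ccc(Cc3ccc(C(O)C(F)(F)F)cc3)cc2)[nH]c2cccc(F)c2c1=O` gives > 10000 nM, a limit of the assay.
compound 3 `CN=S(=O)(c1ccc(Cc2ccc(-c3[nH]c4cccc(F)c4c(=O)c3C)cc2)cc1)C(F)(F)F` gives > 10000 nM, a limit of the assay.

In an ADME assay on Huh7.5.1 cells (Homo sapiens) for cytotoxicity, read by WST assay, with a stated time of 48 h (a lower number here means that less compound is tolerated, a higher number that more compound is tolerated), compound 1 stands only at a limit, not at a number. It sits at the limit of > 2500 nM in this assay, at which 1 of the 3 values shown sits, alone among the three. Compounds 2 and 3 sit at the limit of > 10000 nM in this assay, at which 2 of the 3 values shown sit. Hence the steps a step that the two limits leave unreadable from compound 1 to compound 2 and a step that the two limits leave unreadable from compound 1 to compound 3 cannot be read, and a step that the two limits leave unreadable from compound 2 to compound 3 neither.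

Compound 4 `Cc1c(-c2ccc(Cc3ccc(OC(F)F)cc3)cc2)[nH]c2cccc(F)c2c1=O` differs from compound 1 by difluoromethoxy in place of 1-hydroxy-1-(trifluoromethyl)ethyl on an aromatic carbon. Within the data shown here, no measured step bears directly on this change, and all three values end at a limit, so in this assay no step beyond the scatter is expected. Compound 4 is expected to give 10000 nM, with a range from 2500 nM to 30000 nM. That corresponds to an estimated step that the limit leaves unreadable from compound 1 to compound 4.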

Compound 4, half-maximal cytotoxic concentration: > 5000 nM
Compound 4: no number, only a limit; the forecaster's own chance of this, stated with the estimate: 80%; the middle value is on the limit's open side.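

In this assay compound 4 gives > 5000 nM, a limit and not a number. Its steps with compound 1, compound 2 and compound 3 cannot be read. The compounds shown leave open whether these four differ at all in tolerated concentration.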